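Methoxymethyl to hydroxymethyl on a shared core

A few compounds are considered here, and "the series" means these few. Any claim that something is new, unique, unknown or untested is made for them only; others in the source may bear on it.

Of the compounds shown here, three built on the shared core have been measured so far in a functional assay on DU-145 cells (Homo sapiens) for cytotoxicity, read by sulforhodamine B assay, with a stated time of 3 days (on this read-out higher numbers stand for an effect only at larger amounts of compound and lower numbers for an effect already at smaller amounts), and their numbers lie close together. Compound 1 (`COc1c(-c2occ(C)c2C(=O)O)ccc2c1CCCC2(C)C`) gives 34.1 uM in this test, compound 2 (`Cc1coc(-c2ccc3c(c2O)CCCC3(C)C)c1CO`) gives 22.7 uM in this test, and compound 3 (`COCc1c(C)coc1-c1ccc2c(c1OC)CCCC2(C)C`) gives 17.5 uM in this test. Compound 3 stands within the scatter of both others, so these numbers set no order among the three.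

Compound 4 (`COc1c(-c2occ(C)c2CO)ccc2c1CCCC2(C)C`) has not yet been measured. It has hydrogen in place of methyl on an oxygen on a saturated carbon of compound 3, which turns methoxymethyl into hydroxymethyl (hydrogen in place of methyl on an oxygen on a saturated carbon). Among the measured compounds shown here, no measured step isolates this exact change. The nearest evidence is a 1.9-fold lower number from compound 1 to compound 3 (0.29 log units; within the scatter) at the same group, and that step stays within the scatter. Compound 2 also carries hydroxymethyl, and its 22.7 uM lies within the scatter of compound 3 as well.

On this evidence no step beyond the scatter is expected in this assay and no firm direction can be given. The expected step is a 1.1-fold higher number from compound 3 to compound 4 (0.06 log units; within the scatter) on this estimate. The estimate for compound 4 is 20 uM with an expected range from 10 uM to 38 uM as its bounds.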

Compound 4, concentration for half-maximal effect: 21.7 uM
The estimate for compound 4 lay 1.1-fold (0.04 log units) below the measured number, and the stated range covers the measured number.
By their numbers in this assay, from the lowest: compounds 3, 4, 2 and 1 (each within the scatter of the next).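

In this assay the change from methoxymethyl to hydroxymethyl now has a measured step of its own (a 1.2-fold higher number from compound 3 to compound 4 (0.09 log units; within the scatter)), and taking the methyl off this oxygen on a saturated carbon leaves the number within the scatter. With the change from carboxy to hydroxymethyl also measured (a 1.6-fold lower number from compound 1 to compound 4 (0.20 log units; within the scatter)), carboxy, methoxymethyl and hydroxymethyl at this aromatic carbon all stand within the scatter of one another, and the second methyl, on an oxygen on an aromatic ring, makes no readable difference either (a 1.0-fold lower number from compound 2 to compound 4 (0.02 log units; within the scatter)). Nothing available explains why these steps are so small or otherwise bears on this result.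

The compounds shown leave open whether any group at this carbon would take the number beyond the scatter, since an amine such as aminomethyl or a longer chain such as ethoxymethyl does not appear among them. They also leave open whether the flat picture seen here for hydroxymethyl, methoxymethyl and carboxy would hold on any other cell line.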